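Methoxyphenyl positional isomers in a cytotoxicity series

The compounds below may be only part of what the source reports. "The series", "measured", "known", "first", "only" and "open" are said of these compounds alone.

Measured so far:
compound 1 `Cc1ccc(-c2nnc(N3CCN(C(=O)CN4CCN(c5ccc([N+](=O)[O-])cc5)CC4)CC3)nc2-c2ccc(C)cc2)cc1` — in an ADME assay on NIH3T3 cells (Mus musculus) for cytotoxicity, read by MTT assay, with a stated time of 24 h (on this read-out lower numbers stand for stronger inhibition and higher numbers for weaker inhibition), compound 1 gives > 844000 nM, a limit of the assay, not a number.
compound 2 `COc1ccc(-c2nnc(N3CCN(C(=O)CN4CCN(c5ccccc5OC)CC4)CC3)nc2-c2ccc(OC)cc2)cc1` — in this assay compound 2 gives > 821000 nM, also a limit.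

Within the data shown here, compound 2 stands at the limit of > 821000 nM in this assay, at which 1 of the 2 values shown sits; the only other value shown is the limit of > 844000 nM in this assay, at which 1 of the 2 values shown sits, so the two values show no separation and no step beyond the scatter can be read from them.

Compound 3 `COc1ccc(-c2nnc(N3CCN(C(=O)CN4CCN(c5cccc(OC)c5)CC4)CC3)nc2-c2ccc(OC)cc2)cc1` differs from compound 2 by 3-methoxyphenyl in place of 2-methoxyphenyl on an amine nitrogen in a ring. Among the measured compounds shown here, no step between measured compounds is known. In this assay no step beyond the scatter is expected, in either direction. Compound 3 is expected at 850000 nM, with a range from 400000 nM to 2000000 nM, most likely reported again only as a limit. This corresponds to an expected step that the limit leaves unreadable from compound 2 to compound 3.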

Compound 3, half-maximal inhibitory concentration: > 821000 nM
Compound 3 was reported as a limit; the forecaster's own chance of this, stated with the estimate: 85%; the middle value lies beyond the limit too.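

In this assay, compound 2 and compound 3 are both reported only as limits, so no step can be read between them. The compounds shown leave open whether 3-methoxyphenyl in place of 2-methoxyphenyl changes cytotoxicity at all, and at what concentration either compound would inhibit.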